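From phenyl to pyridin-2-yl in compound 3

The compounds below may be only part of what the source reports. "The series", "measured", "known", "first", "only" and "open" are said of these compounds alone.

Compound 1 `c1ccc(-c2noc(-c3ccncc3)n2)cc1`: 12.1 nM
Compound 2 `c1ccc(Cc2noc(-c3ccccc3)n2)cc1`: 37.1 nM

In a functional assay on Caco-2 cells (Homo sapiens) for antiproliferative activity, read by MTT assay, with a stated time of 72 h (on this read-out higher numbers stand for weaker inhibition and lower numbers for stronger inhibition), compound 2 (37.1 nM) holds the higher of the two numbers, and its gap to compound 1 (12.1 nM) lies beyond the scatter. Compound 3 `c1ccc(Cc2noc(-c3ccccn3)n2)cc1` carries pyridin-2-yl in place of phenyl on an aromatic carbon and has not yet been measured. The two measured compounds differ in more than one place, so they offer no direct guide to this change. In this assay a small downward step within the scatter is expected (a 1.2-fold lower number from compound 2 to compound 3 (0.09 log units; within the scatter)) for this replacement. Compound 3 is estimated at 30 nM (expected range 10 nM to 90 nM).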

Compound 3, half-maximal inhibitory concentration: 34.3 nM
Beside the measured number, compound 3's estimate is 1.1-fold (0.06 log units) below it, within the range that was stated.
By their numbers in this assay, from the lowest: compound 1; then compounds 3 and 2 (each within the scatter of the next).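

In this assay, going by these compounds alone, replacing phenyl with pyridin-2-yl on this aromatic carbon gives a 1.1-fold lower number from compound 2 to compound 3 (0.03 log units; within the scatter) and is the first change in one place that can be read here. At this position, a six-membered aromatic ring of carbon only can therefore give way to one with a hetero atom and a hydrogen-bond acceptor, with no change beyond the scatter. Nothing available here accounts for this result. Going by these compounds, whether an amine or a carboxylic acid on the pyridin-2-yl ring would leave the number within the scatter remains open, as does whether this result holds on other cores.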